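From amino to 4-carboxyphenyl on the shared core

The source may hold more compounds than are shown below. What is called first, only, known or untested is meant among the compounds shown, and "the series" means these compounds.

- compound 1 `O=C1Nc2ccc(S(=O)(=O)N3CCOCC3)cc2/C1=N/c1ccc(O)cc1` gives 259000 nM
- compound 2 `N/N=C1\C(=O)Nc2ccc(S(=O)(=O)N3CCOCC3)cc21` gives 391000 nM

In an ADME assay on WI-38 cells (Homo sapiens) for cytotoxicity, read by sulforhodamine B assay, with a stated time of 24 h (a lower number here means a stronger inhibitor, a higher number a weaker inhibitor), compound 2 lies within the usual scatter of compound 1. Compound 3 `O=C1Nc2ccc(S(=O)(=O)N3CCOCC3)cc2/C1=N/c1ccc(C(=O)O)cc1` keeps the shared core and changes one group (4-carboxyphenyl in place of amino on a double-bonded nitrogen). Within the data shown here, the one measured step that bears on this is amino in place of 4-hydroxyphenyl on the same double-bonded nitrogen (a 1.5-fold higher number from compound 1 to compound 2 (0.18 log units; within the scatter)). That step was small, and the data hold no step beyond the scatter at this place. A change no larger than the scatter is therefore expected (a 1.3-fold lower number from compound 2 to compound 3 (0.12 log units; within the scatter)). Compound 3 is estimated at 300000 nM (range 120000 nM to 700000 nM).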

Compound 3, half-maximal inhibitory concentration: 313000 nM
The estimate for compound 3 lay 1.0-fold (0.02 log units) below the measured number; low and high end bracket the measured number.
By their numbers in this assay, from the lowest: compounds 1, 3 and 2 (each within the scatter of the next).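

In this assay, replacing amino with the much larger 4-carboxyphenyl on the double-bonded nitrogen gives a 1.2-fold lower number from compound 2 to compound 3 (0.10 log units; within the scatter) and so shows that even adding an aromatic ring need not shift the number beyond the scatter. Carboxy in place of hydroxy on an aromatic carbon, a comparison the earlier pair did not offer, gives a 1.2-fold higher number from compound 1 to compound 3 (0.08 log units; within the scatter) and is equally small. Nothing available explains why these changes matter so little. The compounds shown leave open whether a longer chain on the double-bonded nitrogen, or an amine on the aromatic ring, would move the number beyond the scatter.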